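Amide nitrogen substituent and efficacy at free fatty acid receptor 2

The compounds below may be only part of what the source reports. "The series", "measured", "known", "first", "only" and "open" are said of these compounds alone.

Compound 1, `CC(C)[C@H](C(=O)NC(C)(C)C)c1ccc(Cl)cc1`: in a functional assay on CHO cells for agonist activity at Free fatty acid receptor 2 (Homo sapiens), read by cAMP accumulation (a lower number here means a smaller maximal response, a higher number a larger maximal response), compound 1 gives only a limit, < 30%.
Compound 2, `CC(C)[C@H](C(=O)Nc1cccnn1)c1ccc(Cl)cc1`: in this assay compound 2 gives 101%.
Compound 3, `CC(C)[C@H](C(=O)Nc1ccon1)c1ccc(Cl)cc1`: in this assay compound 3 gives 90%.

Compound 3 holds the lower of the two numbers; compound 2 sits nearest, the step being a number 11 percentage points lower from compound 2 to compound 3 (beyond the scatter). Compound 1 stays at a limit (the limit of < 30% in this assay, at which 1 of the 3 values shown sits), so the step of a number at least 60 percentage points higher from compound 1 to compound 3 (beyond the scatter) is known only as a lower bound.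

Compound 4, `CC(C)[C@H](C(=O)NC1=NC(=O)CS1)c1ccc(Cl)cc1`, differs from compound 3 at the amide nitrogen: a group of 6 heavy atoms (3 carbon, 1 nitrogen, 1 oxygen, 1 sulfur; one five-membered non-aromatic ring with 2 hetero atoms) in place of a group of 5 heavy atoms (3 carbon, 1 nitrogen, 1 oxygen; one five-membered aromatic ring with 2 hetero atoms), on an amide-type nitrogen. The measured steps that bear on this position are large where the tert-butyl group is exchanged, a number at least 71 percentage points higher from compound 1 to compound 2 (beyond the scatter), and modest between the two five-membered heterocycles, a number 11 percentage points lower from compound 2 to compound 3 (beyond the scatter). Both heterocyclic amides keep high efficacy, so a modest drop or no step beyond the scatter is expected for compound 4, as a number 15 percentage points lower from compound 3 to compound 4 (beyond the scatter). Compound 4 is therefore estimated at 75%, within 35% to 105%.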

Compound 4, largest response reached (reported as efficacy), in percent of the reference or control that the assay uses: 96%
Beside the measured number, compound 4's estimate is 21 percentage points below it, within the range that was stated.
By their numbers in this assay, from the lowest: compounds 3, 4 and 2 (each within the scatter of the next, the first and the last beyond it). At a limit, below all of these: compound 1.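

A non-aromatic five-membered ring on the amide-type nitrogen reads the same as both aromatic heterocycles in this assay: a number 6 percentage points higher from compound 3 to compound 4 (within the scatter) and a number 5 percentage points lower from compound 2 to compound 4 (within the scatter). High efficacy in this set therefore does not depend on an aromatic ring at this position. The step of a number at least 66 percentage points higher from compound 1 to compound 4 (beyond the scatter) is large but only a lower bound, since compound 1 stands at a limit: the limit of < 30% in this assay, at which 1 of the 4 values shown sits.

As far as these compounds go, whether the ring or its hetero atoms carry the high efficacy stays open. Also open, from the compounds shown here alone, is how a plain phenyl ring or a longer alkyl chain on the amide-type nitrogen would read in this assay.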